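The source may report more compounds than this note shows. Statements on the series, on what has been measured and on what is new or still open speak of the compounds shown alone.

Measured compounds:
- compound 1, `C=C1C(=O)O[C@H](c2ccc3ccccc3c2)[C@H]1C`: 1%
- compound 2, `C=C1C(=O)O[C@@H](c2ccccc2)[C@H]1c1ccccc1`: 8%

In a functional assay on BXPC-3 cells (Homo sapiens) for cytotoxicity, read by MTT assay, with a stated time of 72 h, tested at 10 uM (on this read-out higher numbers stand for a weaker effect at the one concentration tested and lower numbers for a stronger effect), compound 1 gives 1%, the lower of the two numbers recorded. Its nearest neighbour is compound 2, which in this assay gives 8%; the two values lie within the scatter of each other, so no order between them can be read from these numbers. Both compounds share the same core, and both register a strong effect on this read-out at the single concentration tested.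

Compound 3, `C=C1C(=O)O[C@H](c2ccc3ccccc3c2)[C@H]1c1ccccc1`, has not yet been measured. It differs from compound 1 in one place: phenyl in place of methyl on a saturated ring carbon. Compound 3 thus carries the naphthyl group of compound 1 together with the phenyl group that compound 2 bears on the same saturated ring carbon.

Within the data shown here, with only two measured compounds and no step between them, the data give no measured direction for this change. Since compound 1 at 1% and compound 2 at 8% both sit low, compound 3 is expected to remain in that region, with a step of a number 3 percentage points higher from compound 1 to compound 3 (within the scatter) that stays within the scatter. Compound 3 is therefore estimated at 4%, in a range from 0% to 20%.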

Compound 3, a percentage reported as activity, at one concentration (the size of the read-out at that concentration, not a potency): 1%
Estimate against measurement, compound 3: 3 percentage points above; the range from low to high includes it.
By their numbers in this assay, from the lowest: compounds 1, 3 and 2 (each within the scatter of the next).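

In this assay the exchange of methyl for phenyl on this saturated ring carbon gives no change at the digits printed from compound 1 to compound 3 (within the scatter) with the naphthyl group held constant, so at the one concentration tested this position accepts the larger aromatic group and the effect remains as strong as it was with methyl. The earlier compounds shown here could not show this: compound 1 and compound 2 differ in more than one place, and no step between them isolated the group on this carbon. Nothing measured in the material shown offers an explanation for this result.

From the compounds shown here alone, what remains open is whether a group of another kind on the same carbon, such as an amine, a carboxylic acid or a longer chain, would leave the read-out where compound 1 and compound 3 stand. A single concentration also gives no potency, so any difference in potency between compound 1 and compound 3 could lie hidden at this dose, and whether the same exchange would behave alike with a group other than naphthyl on the shared core cannot be told from these compounds.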